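From Compound 3 to Compound 4: An Expected Tolerance Limit

The source may report more compounds than this note shows. Statements on the series, on what has been measured and on what is new or still open speak of the compounds shown alone.

Three compounds sharing one core were tested in an ADME assay on Vero cells (Chlorocebus sabaeus) for cytotoxicity, read by MTT assay, with a stated time of 72 h; a higher number here means that more compound is tolerated, a lower number that less compound is tolerated. Compound 1 `COC(=O)c1cc(-c2cccc(NC(=O)c3ccc(/C=C/C(=O)c4ccc(C)cc4)cc3)c2)on1` gives > 80 ug/mL in this assay, and that figure is a limit of the assay rather than a number. Compound 2 `COC(=O)c1cc(-c2cccc(NC(=O)c3ccc(/C=C/C(=O)c4ccc(C)c(F)c4)cc3)c2)on1` gives > 50 ug/mL in this assay, again only a limit. Compound 3 `COC(=O)c1cc(-c2cccc(NC(=O)c3ccc(/C=C/C(=O)c4ccc(OC)cc4OC)cc3)c2)on1` gives > 50 ug/mL in this assay, also a limit. Compound 3 therefore stands only at a limit, and the two other values are limits as well. The steps a step that the two limits leave unreadable from compound 1 to compound 2, a step that the two limits leave unreadable from compound 1 to compound 3 and a step that the two limits leave unreadable from compound 2 to compound 3 cannot be read because two values sit at the limit of > 50 ug/mL in this assay, at which 2 of the 3 values shown sit, and one at the limit of > 80 ug/mL in this assay, at which 1 of the 3 values shown sits. Compound 4 `COC(=O)c1cc(-c2cccc(NC(=O)c3ccc(/C=C/C(=O)c4ccc(CC(C)C)cc4)cc3)c2)on1` differs from compound 3 in one place, namely (4-isobutylphenyl in place of 2,4-dimethoxyphenyl on a carbonyl carbon). For the measured compounds named here, no measured step shows what this change does to tolerance. Compound 4 is expected to remain near a limit, at about 60 ug/mL in this assay. The step that the limit leaves unreadable from compound 3 to compound 4 is expected to stay within the scatter. The range for compound 4 is estimated from 30 ug/mL to 100 ug/mL.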

Compound 4, half-maximal cytotoxic concentration: > 10 ug/mL
Compound 4 gave a limit, no number; the forecaster's own chance of this, stated with the estimate: 75%; the middle value does not contradict the limit.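

For the compounds shown here, compound 4 also stands only at a limit, so no step from compound 1, compound 2 or compound 3 to compound 4 can be read. The compounds shown leave open how much of each is actually tolerated in this assay, and whether any of these group changes alters that.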